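The source may hold more compounds than are shown below. What is called first, only, known or untested is meant among the compounds shown, and "the series" means these compounds.

Measured so far in a functional assay on the whole organism (strain Wistar) for inhibition, with Rattus norvegicus as the target, read by paw edema, with a stated time of 2 h, at a dose of 10 mg/kg by the intraperitoneal route; a higher number here means more inhibition at the dose given (going by the name of the read-out), a lower number less inhibition: compound 1 `O=C(N/N=C/c1cccc(O)c1)c1cccnc1Nc1cccc(C(F)(F)F)c1` gives 65.4%; compound 2 `O=C(N/N=C/c1ccc(O)c(O)c1)c1cccnc1Nc1cccc(C(F)(F)F)c1` gives 46.9%.

Among the compounds with values here, compound 2 stands lowest of the two numbers in this assay; its nearest neighbour is compound 1, and the one measured step is a number 18.5 percentage points lower from compound 1 to compound 2 (beyond the scatter). Compound 3 `COc1ccc(/C=N/NC(=O)c2cccnc2Nc2cccc(C(F)(F)F)c2)cc1` is not yet measured. Change: 4-methoxyphenyl in place of 3,4-dihydroxyphenyl on a carbon with a double bond to nitrogen. Within the data shown here, only that single step bears on it: a hydroxy entering cost a modest amount, and here both hydroxy groups leave, so a modest rise in this assay is expected, roughly a number 13.1 percentage points higher from compound 2 to compound 3 (beyond the scatter). Compound 3 is therefore estimated at 60%, with a range of 45% to 75%.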

Compound 3, a percentage reported as inhibition, in the whole organism at one dose (the size of the read-out at that dose, not a potency): 42.4%
Compound 3: the middle estimate sits 17.6 percentage points above what was measured; measured number below the stated range.
By their numbers in this assay, from the lowest: compounds 3 and 2 (each within the scatter of the next); then compound 1.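

In this assay the change to 4-methoxyphenyl gives a number 4.5 percentage points lower from compound 2 to compound 3 (within the scatter) and so does not bring back the level of compound 1. Within the data shown here, the same group in place of 3-hydroxyphenyl gives a number 23 percentage points lower from compound 1 to compound 3 (beyond the scatter) and leaves 3-hydroxyphenyl as the only one of the three groups that stands apart, while compound 2 with its hydroxy groups and compound 3 with none lie within the scatter of each other, so the hydroxy count alone does not order these compounds. Nothing at hand explains what sets 3-hydroxyphenyl apart.

Open, on these data alone, is whether the hydroxy group of compound 1 itself is needed on a carbon with a double bond to nitrogen's aromatic substituent, and how an amine or a carboxylic acid in its place would read in this assay on the same core.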